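The compounds below may be only part of what the source reports. "The series", "measured", "known", "first", "only" and "open" are said of these compounds alone.

Measured so far:
compound 1 `O=C(O)Cc1sc(C(c2ccccc2)c2ccccc2)nc1-c1ccccc1`: 80%
compound 2 `O=C(O)Cc1sc(C(c2ccc(F)cc2)c2ccc(F)cc2)nc1-c1ccnc(N2CCC2)c1`: 80%
compound 3 `O=C(O)Cc1sc(C(c2ccccc2)c2ccccc2)nc1-c1ccc(C(F)(F)F)cc1`: 80%

Three variants of the shared core have been run in an in vitro functional assay on HEK285-7 cells for antagonist activity at prostaglandin D2 receptor 2 (Homo sapiens), read by BRET and beta-arrestin recruitment (a higher number here means a larger maximal response, a lower number a smaller maximal response), and all three reach the same maximal response at the digits reported. Compound 2 stands level with compound 1 and with compound 3; none of the three separates from the others beyond the scatter. Among the compounds with values here, the only single-point step among them, no change at the digits printed from compound 1 to compound 3 (within the scatter), shows that trifluoromethyl in place of hydrogen on an aromatic carbon left the maximal response unchanged.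

Compound 4 `Nc1cc(-c2nc(C(c3ccc(F)cc3)c3ccc(F)cc3)sc2CC(=O)O)cc(F)n1` is the next member. It differs from compound 2 by 2-amino-6-fluoropyridin-4-yl in place of 2-(azetidin-1-yl)pyridin-4-yl on an aromatic carbon. Within the data shown here, no measured step covers an exchange of this kind; what bears on it is only the general picture, in which three differently substituted variants of the core all give the same maximal response, and the one single-point step, no change at the digits printed from compound 1 to compound 3 (within the scatter), is flat. On that basis the step of no change at the digits printed from compound 2 to compound 4 (within the scatter) is expected to stay within the scatter. Compound 4 is therefore estimated at 80%, with a range from 66% to 92%.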

Compound 4, largest response reached (reported as efficacy), in percent of the reference or control that the assay uses: 30%
Beside the measured number, compound 4's estimate is 50 percentage points above it, outside the stated range (below it).
By their numbers in this assay, from the lowest: compound 4; then compounds 1, 2 and 3 (each within the scatter of the next).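

In this assay, the position on the aromatic carbon next to the ring nitrogen turns out not to be indifferent to its substituent: a number 50 percentage points lower from compound 2 to compound 4 (beyond the scatter) follows the exchange of 2-(azetidin-1-yl)pyridin-4-yl for 2-amino-6-fluoropyridin-4-yl. Within the data shown here, this is the first step beyond the scatter, whereas no change at the digits printed from compound 1 to compound 3 (within the scatter) showed only that trifluoromethyl in place of hydrogen on an aromatic carbon changes nothing at this read-out. No measurement at hand accounts for the step.

The exchange removes the azetidine ring and brings in both an amino group and a fluorine at once, so the compounds shown cannot assign the step to any one of these. A pyridin-4-yl carrying the amino group alone, or the fluorine alone, would separate the two.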